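Working notes: adding dimethylamino to compound 2

This account rests on a few compounds, and the source may have more. Where it says the series, first, only, none or still open, it means among the compounds named here.

Measured in a functional assay on A549 cells (Homo sapiens) for antiproliferative activity, read by MTT assay, with a stated time of 48 h; a lower number here means a stronger inhibitor, a higher number a weaker inhibitor:
- compound 1 `Cc1cccn2cc(-c3nnc(-c4ccccc4I)o3)nc12`: 33400 nM
- compound 2 `Cc1cc(Br)c2nc(-c3nnc(-c4ccccc4)o3)cn2c1`: 14500 nM

Of these two numbers, compound 2 holds the lower, at 14500 nM, and the gap to compound 1 lies beyond the scatter. The two compounds differ in more than one place, so no single structural change has a measured size in this series.

The next compound to be measured is compound 3 `Cc1cc(Br)c2nc(-c3nnc(-c4ccc(N(C)C)cc4)o3)cn2c1`. Relative to compound 2, it carries dimethylamino in place of hydrogen on an aromatic carbon of a six-membered aromatic ring of carbon only, para to a large group (dimethylamino in place of hydrogen on an aromatic carbon).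

Among the compounds with values here, with no measured step to draw on, no shift beyond the scatter is expected in this assay, with only a slight lean towards a lower number. The expected change is a 1.3-fold lower number from compound 2 to compound 3 (0.12 log units; within the scatter). The uncertainty is wide, since this estimate has only the value of compound 2 as its anchor. For compound 3 the estimated value is 11000 nM, with an expected range of 4000 nM to 30000 nM.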

Compound 3, half-maximal inhibitory concentration: 10800 nM
Estimate against measurement, compound 3: 1.0-fold (0.01 log units) above, and the stated range covers the measured number.
By their numbers in this assay, from the lowest: compounds 3 and 2 (each within the scatter of the next); then compound 1.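

In this assay, dimethylamino in place of hydrogen on an aromatic carbon of the six-membered aromatic ring of carbon only, para to a large group, gives a 1.3-fold lower number from compound 2 to compound 3 (0.13 log units; within the scatter). Within the data shown here, this is the first step with a measured size for a change in one place, and it shows that this replacement at this position leaves the number within the scatter, so compounds 2 and 3 cannot be told apart in this assay's read-out. No measurement at hand bears on what lies behind this result.

Going by these compounds, whether a different group at the same place, such as a carboxylic acid, a morpholine ring or a longer chain ending in an amine, would move the number beyond the scatter remains open. Also open, on these data alone, is whether dimethylamino would give a step of similar size on a different parent, since this single step comes from compound 2 alone.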